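The source may report more compounds than this note shows. Statements on the series, on what has been measured and on what is new or still open speak of the compounds shown alone.

Compound 2 `COc1cccc(CNCCCNc2ccnc3cc(Oc4cccc(N(C)C)c4)ccc23)c1O` stands highest of the two compounds measured in a physicochemical assay for solubility, with a stated time of 18 h, at pH 7.4 (on this read-out higher numbers stand for higher solubility and lower numbers for lower solubility), where compound 2 gives 14500 nM. For the measured compounds named here, its nearest neighbour, compound 1 `COc1cccc(CNCCCNc2ccnc3cc(CCC(C)C)ccc23)c1O`, gives 4200 nM in this assay, and the single change between them, 3-(dimethylamino)phenoxy in place of isopentyl on an aromatic carbon, brought a 3.5-fold higher number from compound 1 to compound 2 (0.54 log units; beyond the scatter). Compound 3 `COc1cccc(CNCCCNc2ccnc3cc(CC(C)C)ccc23)c1O` has not yet been measured. It differs from compound 2 in one place: isobutyl in place of 3-(dimethylamino)phenoxy on an aromatic carbon. Going by the values given here, the only measured step that bears on this change is the one that put the 3-(dimethylamino)phenoxy group in, a 3.5-fold higher number from compound 1 to compound 2 (0.54 log units; beyond the scatter), and taking that group out again for isobutyl is expected to give back most of that gain. For compound 3 the expected step is therefore a 2.9-fold lower number from compound 2 to compound 3 (0.46 log units; beyond the scatter), a fall in this assay beyond the scatter. Compound 3 is estimated at 5000 nM, with a range from 2000 nM to 12000 nM.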

Compound 3, solubility: 4200 nM
Beside the measured number, compound 3's estimate is 1.2-fold (0.08 log units) above it; the measured number falls inside the stated range.
By their numbers in this assay, from the lowest: compounds 1 and 3 (each within the scatter of the next); then compound 2.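

In this assay, isobutyl in place of the 3-(dimethylamino)phenoxy group gave a 3.5-fold lower number from compound 2 to compound 3 (0.54 log units; beyond the scatter), so the difference seen earlier against isopentyl now also appears against a second alkyl chain. Comparing those two chains directly gave no change at the digits printed from compound 1 to compound 3 (within the scatter), which means that isopentyl and isobutyl cannot be told apart at this position and that compound 2 alone stands apart from them. Nothing available here explains why the 3-(dimethylamino)phenoxy group gives the higher number.

On these data alone, what stays open is which part of that group matters, its aromatic ring or its dimethylamino nitrogen. A plain phenoxy group and a dimethylaminoethyl chain at the same position would separate the two, and a carboxylic acid there would test a quite different kind of group.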